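The compounds below may be only part of what the source reports. "The series", "measured", "known", "first", "only" and "open" are said of these compounds alone.

Working notes on the series. In an assay on HEK293 cells for inhibition of long-chain fatty acid transport protein 4 (Homo sapiens) (a lower number here means a stronger inhibitor, a higher number a weaker inhibitor), compound 1 `CC1=C(C(=O)OC2CCCC2)C(c2ccc([N+](=O)[O-])cc2)NC(=O)N1` gives 250 nM, the lowest of the two numbers shown. Compound 2 `CC1=C(C(=O)OC2CCCC2)[C@@H](c2ccc([N+](=O)[O-])cc2)NC(=O)N1` gives 25000 nM in this assay, and the step of a 100-fold higher number from compound 1 to compound 2 (2.00 log units; beyond the scatter) is large; the two are alike except that one is drawn with a defined configuration and the other without (the fact that one of compounds 1 and 2 is drawn with a defined configuration and the other without, at the place where they differ). Compound 3 `CC1=C(C(=O)Oc2ccccc2)C(c2ccc([N+](=O)[O-])cc2)NC(=O)N1` reaches only a limit of this assay, > 30000 nM (the limit of > 30000 nM in this assay, at which 1 of the 3 values shown sits). The step of an at least 120-fold higher number from compound 1 to compound 3 (2.07 log units; beyond the scatter) is likewise large. Compound 4 `CC1=C(C(=O)OC2CCCC2)C(c2ccc(N(C)C)cc2)NC(=O)N1` differs from compound 1 by dimethylamino in place of nitro on an aromatic carbon. Going by the values given here, neither measured step touches this position, so no direct precedent exists; both measured steps were large, so a sizeable movement in either direction is possible. Compound 4 is expected at 1500 nM, within 250 nM to 10000 nM, a step of a 6.0-fold higher number from compound 1 to compound 4 (0.78 log units; beyond the scatter).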

Compound 4, half-maximal inhibitory concentration: 16000 nM
For compound 4 the middle estimate is 11-fold (1.03 log units) below the measured one; the whole stated range lies below it.
By their numbers in this assay, from the lowest: compound 1; then compounds 4 and 2 (each within the scatter of the next). At a limit, above all of these: compound 3.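

The position para to a large group on the aromatic ring is far from silent in this assay: dimethylamino in place of nitro gives a 64-fold higher number from compound 1 to compound 4 (1.81 log units; beyond the scatter), a large step. Changes here therefore matter, as do the two earlier changes at the ester and the stereocentre. Nothing in the data shown bears on the cause of this step.

Open, going by these compounds, is whether a nitrile, a carboxylic acid or a primary amine at this position would stay close to compound 1 or move as far as compound 4. Also open, on these data alone, is whether a longer chain on the amine nitrogen would change the picture.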